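The source may hold more compounds than are shown below. What is called first, only, known or untested is meant among the compounds shown, and "the series" means these compounds.

Of the compounds shown here, two have numbers so far in an assay on isolated protein for inhibition of matrix metalloproteinase-9 (Homo sapiens), read by colorimetric assay; on this read-out higher numbers stand for weaker inhibition and lower numbers for stronger inhibition. Compound 1 `O=C(Cn1c(=O)c(Cc2ccccc2)nc2ccccc21)NNC(=S)Nc1ccccc1` gives 8.41 nM, the lowest of the two, while compound 2 `COc1cc(/C=N/NC(N)=S)ccc1O` gives 106 nM, a gap beyond the scatter. Compound 3 `Cc1ccc(C(=O)NNC(=O)Cn2c(=O)c(Cc3ccccc3)nc3ccccc32)cc1` has not yet been measured. Relative to compound 1 it carries a group of 9 heavy atoms (8 carbon, 1 oxygen; one six-membered aromatic ring of carbon only) in place of a group of 9 heavy atoms (7 carbon, 1 nitrogen, 1 sulfur; one six-membered aromatic ring of carbon only), on an amine nitrogen, on an amine nitrogen. For the measured compounds named here, no measured pair shows this kind of exchange, so the expected step is uncertain, but a moderate weakening beyond the scatter seems the likelier outcome, giving an estimated step of a 3.0-fold higher number from compound 1 to compound 3 (0.47 log units; beyond the scatter). Compound 3 is therefore expected to give about 25 nM, with a range from 8 nM to 80 nM.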

Compound 3, half-maximal inhibitory concentration: 23.1 nM
Estimate against measurement, compound 3: 1.1-fold (0.03 log units) above, and the stated range covers the measured number.
By their numbers in this assay, from the lowest: compound 1; then compound 3; then compound 2.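

Exchanging the sulfur-bearing group on this amine nitrogen for (4-methylphenyl)carbonyl gives a 2.7-fold higher number from compound 1 to compound 3 (0.44 log units; beyond the scatter) in this assay. This first one-place comparison shows that the position accepts a group without sulfur and without a hydrogen-bond donor at a modest loss, though one still beyond the scatter. No measured evidence explains the step.

As far as these compounds go, the exchange alters several features at once, so their separate contributions remain open. A group keeping the ring nitrogen with a carbonyl in place of the sulfur, or a small acetyl group, could help separate them.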